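A few compounds are considered here, and "the series" means these few. Any claim that something is new, unique, unknown or untested is made for them only; others in the source may bear on it.

Measured so far:
- compound 1, `Cc1csc(C2=NNC(c3ccc(N4CCCCC4)cc3)C2)c1`: 31600 nM
- compound 2, `Cc1cc(C2=NNC(c3ccc(N4CCCCC4)cc3)C2)c(C)s1`: 83400 nM
- compound 3, `Clc1ccsc1C1=NNC(c2ccc(N3CCCCC3)cc2)C1`: 31600 nM

In an ADME assay on Vero cells (Chlorocebus sabaeus) for cytotoxicity, with a stated time of 5 days (a higher number here means a weaker inhibitor, a lower number a stronger inhibitor), compound 3 stands level with compound 1 at the digits shown, the two together the lowest numbers of the three, while compound 2 sits higher, as seen in a 2.6-fold lower number from compound 2 to compound 3 (0.42 log units; beyond the scatter). Compound 4, `Clc1cc(C2=NNC(c3ccc(N4CCCCC4)cc3)C2)c(Cl)s1`, carries the change (2,5-dichlorothiophen-3-yl in place of 3-chlorothiophen-2-yl on a carbon with a double bond to nitrogen). The step that bears on this is the move to a thiophen-3-yl bearing two substituents, a 2.6-fold higher number from compound 1 to compound 2 (0.42 log units; beyond the scatter), whereas no change at the digits printed from compound 1 to compound 3 (within the scatter) shows the single-substituent exchange left the number unchanged. A modest rise in this assay is therefore expected, a 1.6-fold higher number from compound 3 to compound 4 (0.20 log units; within the scatter). Compound 4 is estimated at 50000 nM, with a range from 22000 nM to 110000 nM.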

Compound 4, half-maximal inhibitory concentration: 53900 nM
The estimate for compound 4 lay 1.1-fold (0.03 log units) below the measured number; measured number inside the range.
By their numbers in this assay, from the lowest: compounds 1, 3, 4 and 2 (each within the scatter of the next, the first and the last beyond it).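

In this assay, compound 4 falls within the scatter of all three earlier compounds, so the 2,5-dichlorothiophen-3-yl group separates from neither the 3-chlorothiophen-2-yl group (a 1.7-fold higher number from compound 3 to compound 4 (0.23 log units; within the scatter)) nor the 4-methylthiophen-2-yl group (a 1.7-fold higher number from compound 1 to compound 4 (0.23 log units; within the scatter)). Chlorine in place of methyl on the 2,5-disubstituted thiophen-3-yl also gives no step beyond the scatter (a 1.5-fold lower number from compound 2 to compound 4 (0.19 log units; within the scatter)). Nothing available explains these numbers. On these data alone, whether an amine or a carboxylic acid on the thiophene would move the number beyond the scatter remains open.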